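The compounds below may be only part of what the source reports. "The series", "measured", "known", "first", "only" and "open" are said of these compounds alone.

Compound 1 `Cc1cc(-c2ccc(C(F)(F)F)cc2)nnc1N1CCN(c2ncccn2)CC1` carries a trifluoromethyl-bearing aryl ring on the shared core, and in a functional assay on BV-2 cells (Mus musculus) for inhibition, read by ELISA, with a stated time of 16 h (on this read-out lower numbers stand for stronger inhibition and higher numbers for weaker inhibition), compound 1 gives 37400 nM. Compound 2 `Cc1cc(-c2ccc(F)cc2)nnc1N1CCN(c2ncccn2)CC1` keeps everything except that ring substituent, and in this assay compound 2 gives 76300 nM; the change is a 2.0-fold higher number from compound 1 to compound 2 (0.31 log units; beyond the scatter). Compound 3 `COc1ncc(-c2cc(C)c(N3CCN(c4ncccn4)CC3)nn2)c(OC)n1` reaches only a limit of this assay, > 100000 nM, so no number is known for it; this is the situation described by the limit of > 100000 nM in this assay, at which 1 of the 3 values shown sits. Among the two numbers, compound 2 stands highest, with compound 1 nearest through the step just named.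

Compound 4 `Cc1cc(-c2cc3ccccc3s2)nnc1N1CCN(c2ncccn2)CC1` differs from compound 2 by 1-benzothiophen-2-yl in place of 4-fluorophenyl on an aromatic carbon. Within the data shown here, the only measured step, from compound 1 to compound 2, exchanged one small group on that aryl ring for another and was modest in size; no measured step exchanges the whole ring, as happens here. The step is therefore expected to be a 1.9-fold lower number from compound 2 to compound 4 (0.28 log units; within the scatter), a modest lowering of the number in this assay. For compound 4 the estimated value is 40000 nM, expected to lie between 10000 nM and 100000 nM.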

Compound 4, half-maximal inhibitory concentration: 24900 nM
Compound 4: middle estimate off by 1.6-fold (0.21 log units), on the high side; low and high end bracket the measured number.
By their numbers in this assay, from the lowest: compounds 4 and 1 (each within the scatter of the next); then compound 2. At a limit, above all of these: compound 3.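

Among these compounds, the step of a 3.1-fold lower number from compound 2 to compound 4 (0.49 log units; beyond the scatter) is the first measured exchange of a whole ring at this position, not just of a small group on the ring, and it shows that the position accepts a larger group. In this assay, the aryl ring can give way to 1-benzothiophen-2-yl, with its five-membered aromatic ring joined to a six-membered one, and the number still drops. Compound 4, at 24900 nM, lies within the scatter of compound 1, at 37400 nM, so this ring exchange and the trifluoromethyl-bearing aryl ring cannot be ranked against each other.

The compounds shown cannot separate the part played by the sulfur from that of the added ring, and they leave open how an amine or a carboxylic acid would fare at this position. Compound 3 remains a limit and not a number, so its steps cannot be read: the limit of > 100000 nM in this assay, at which 1 of the 4 values shown sits.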